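A few compounds are considered here, and "the series" means these few. Any claim that something is new, unique, unknown or untested is made for them only; others in the source may bear on it.

Measured compounds:
compound 1, `CN(C)c1ncnc2c1ncn2Cc1ccc([N+](=O)[O-])cc1`: 0%
compound 2, `CN(C)c1ncnc2c1ncn2Cc1ccc(C#N)cc1`: 0%
compound 3, `CN(C)c1ncnc2c1ncn2Cc1cccc([N+](=O)[O-])c1`: 17%

Compound 4, `CN(C)c1ncnc2c1ncn2Cc1cccc(C#N)c1`, is not yet measured.

Compound 1 and compound 2 share one core; compound 3 has the same atoms joined differently, and the difference between the two cores is not broken down here. In a functional assay on the whole organism for inhibition, with Rattus norvegicus as the target, in the maximal electroshock model, at a dose of 25 mg/kg by the intraperitoneal route (on this read-out lower numbers stand for less inhibition and higher numbers for more inhibition at the one dose given (going by the name of the read-out)), compound 1 gives 0% and compound 2 gives 0%. In this assay compound 3 gives 17%, the highest of the three numbers, the other two lying lower by an amount beyond the scatter.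

The step from compound 1 to compound 2 is the change (cyano in place of nitro on an aromatic carbon), and it gave no change at the digits printed from compound 1 to compound 2 (within the scatter). The change leading to compound 4 is cyano in place of nitro on an aromatic carbon, the same kind of change, but placed meta to a large group rather than para to it. For the measured compounds named here, only one occurrence of this change has been measured. Compound 4 is expected to stay close to compound 3, with an expected step of a number 5 percentage points lower from compound 3 to compound 4 (within the scatter) in this assay, because no change at the digits printed from compound 1 to compound 2 (within the scatter) was within the scatter. Compound 4 is estimated at 12%, with a range from 0% to 30%.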

Compound 4, a percentage reported as inhibition, in the whole organism at one dose (the size of the read-out at that dose, not a potency): 17%
Compound 4: middle estimate off by 5 percentage points, on the low side; the range from low to high includes it.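

In this assay, cyano in place of nitro on an aromatic carbon gave no change at the digits printed from compound 3 to compound 4 (within the scatter), and the two cores agree on this step: the same change on two cores in this assay, no change at the digits printed (within the scatter) from compound 1 to compound 2 and no change at the digits printed (within the scatter) from compound 3 to compound 4, 0 percentage points apart, within the scatter of two such steps. On these two cores, then, the change carries over with no difference that can be read, and on the core of compound 3 the reading stays off the bottom of the values seen here. For the compounds shown here, this does not show that the change is neutral on other cores: it rests on only two pairs, and in one of them compound 1 gives 0% and compound 2 gives 0%, so that pair shows nothing about a fall in the reading.

Open, on these data alone, is what an amine or a carboxylic acid on the same aromatic carbon would give in this assay, and whether the two cores would still agree for such a group. Also open, as far as these compounds go, is how these compounds compare at any other dose, since a reading at one dose is not a potency.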